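The source may hold more compounds than are shown below. What is called first, only, known or untested is meant among the compounds shown, and "the series" means these compounds.

Measured compounds:
compound 1 `C#CC1(CO)CC(n2cc(C)c(=O)[nH]c2=O)CC1O`; in an ADME assay on MT4 cells (Homo sapiens) for cytotoxicity, read by luminescence and CellTiter-Glo, with a stated time of 48 h (on this read-out higher numbers stand for lower toxicity in this test and lower numbers for higher toxicity in this test), compound 1 gives > 42000 nM, which is a limit of the assay and not a number.
compound 2 `Cc1cn(C2CC(O)C(C#N)(CO)C2)c(=O)[nH]c1=O`; in this assay compound 2 gives > 42000 nM, again a limit.
compound 3 `C#CC1(CO)CC(n2cnc3c(=O)[nH]c(N)nc32)CC1O`; in this assay compound 3 gives > 42000 nM, again a limit.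

All three values therefore sit at the limit of > 42000 nM in this assay, at which 3 of the 3 values shown sit. The change from compound 1 to compound 2 is cyano in place of ethynyl on a saturated ring carbon, and its step that the two limits leave unreadable from compound 1 to compound 2 is left unreadable by the two limits.

Compound 4 `N#CC1(CO)CC(n2cnc3c(=O)[nH]c(N)nc32)CC1O` has not been measured. Within the data shown here, it differs from compound 3 by cyano in place of ethynyl on a saturated ring carbon, the same kind of change as the one from compound 1 to compound 2; the surroundings differ only in that the ring atom two ring bonds away bears a large group in one case and a group of 9 heavy atoms in the other. The difference between the core of compound 3 and the core of compound 1 is not broken down here.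

The step expected here, a step that the limit leaves unreadable from compound 3 to compound 4, stands beside the unreadable earlier one and rests on compound 3 sitting at the limit of > 42000 nM in this assay, at which 3 of the 3 values shown sit. Compound 4 is thus expected to give about 60000 nM in this assay, estimated between 42000 nM and 200000 nM, most likely reported only as a limit.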

Compound 4, half-maximal cytotoxic concentration: > 42000 nM
Compound 4 ended at the assay's limit; the forecaster's own chance of this, stated with the estimate: 90%; the middle value does not contradict the limit.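

Compound 3 and compound 4 both end at a limit of the assay rather than a number in this assay, so no step can be read between them: the limit of > 42000 nM in this assay, at which 4 of the 4 values shown sit.

Still open is whether cyano in place of ethynyl on a saturated ring carbon changes toxicity at all in this assay, and how toxic any of these compounds would prove beyond that limit.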